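Urea series: removing one trifluoromethyl from the aryl urea

The compounds below may be only part of what the source reports. "The series", "measured", "known", "first", "only" and "open" are said of these compounds alone.

Going by the values given here, compound 1 `O=C(Nc1cccc(-n2cc(-c3ccncc3)c(-c3ccc(Cl)c(O)c3)n2)c1)Nc1cc(C(F)(F)F)cc(C(F)(F)F)c1` gives 2550 nM in a functional assay on UACC-257 cells (Homo sapiens) for inhibition, read by sulforhodamine B assay, with a stated time of 48 h (on this read-out lower numbers stand for stronger inhibition of growth and higher numbers for weaker inhibition of growth), and is the only compound in the set with a number. The other value shown is a limit (the limit of > 100000 nM in this assay, at which 1 of the 2 values shown sits). Compound 2 `COc1cc(-c2nn(-c3cccc(NC(=O)c4ccccc4)c3)cc2-c2ccncc2)ccc1Cl` reaches only the limit > 100000 nM in this assay, which is not a number. Compound 3 `O=C(Nc1cccc(-n2cc(-c3ccncc3)c(-c3ccc(Cl)c(O)c3)n2)c1)Nc1cccc(C(F)(F)F)c1` differs from compound 1 by hydrogen in place of trifluoromethyl on an aromatic carbon. Among the compounds with values here, no measured pair shows this change. The step is expected to be a modest loss, a 2.4-fold higher number from compound 1 to compound 3 (0.37 log units; beyond the scatter), beyond the usual scatter but not large. Compound 3 is expected at 6000 nM, with a range from 2000 nM to 20000 nM.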

Compound 3, concentration for total growth inhibition: 19100 nM
For compound 3 the middle estimate is 3.2-fold (0.50 log units) below the measured one, and the stated range covers the measured number.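

In this assay, going by these compounds alone, hydrogen in place of trifluoromethyl on the aromatic carbon of the aryl urea gives a 7.5-fold higher number from compound 1 to compound 3 (0.87 log units; beyond the scatter), the first measured step at this position. This trifluoromethyl therefore contributes to the growth-inhibition read-out, although the remaining one in compound 3 still leaves a measurable number. Nothing in the data shown bears on the reason for the size of this step.

As far as these compounds go, whether a nitrile or an amine at this carbon would hold the number of compound 1 stays open. So does the effect of replacing the remaining trifluoromethyl in compound 3.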